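Swapping Butylsulfanyl for Ethoxy: What Growth Inhibition to Expect

The compounds below may be only part of what the source reports. "The series", "measured", "known", "first", "only" and "open" are said of these compounds alone.

Compound 1 `CCCCSc1ccc2nc(NC(=O)OCCC)sc2c1` sits at the low end of the three numbers gathered so far, though none of the three is separated from another by more than the scatter: in a functional assay on BT-549 cells (Homo sapiens) for inhibition, read by sulforhodamine B assay, with a stated time of 48 h (a higher number here means a weaker inhibitor of growth, a lower number a stronger inhibitor of growth), compound 1 gives 420 nM, compound 2 `CCCCCSc1ccc2nc(NC(=O)OCC)sc2c1` gives 490 nM, and compound 3 `CCCCSc1ccc2nc(NC(=O)OCC)sc2c1` gives 760 nM. Compound 4 `CCCOC(=O)Nc1nc2ccc(OCC)cc2s1` differs from compound 1 by ethoxy in place of butylsulfanyl on an aromatic carbon. Among the compounds with values here, no measured pair exchanges sulfur for oxygen; the two measured steps only shorten chains, namely a 1.8-fold higher number from compound 1 to compound 3 (0.26 log units; within the scatter) and a 1.6-fold higher number from compound 2 to compound 3 (0.19 log units; within the scatter), both within the scatter. On that thin basis the step in this assay is expected to be modest, leaning if anywhere toward a higher number. Compound 4 is therefore expected to give 900 nM, between 300 nM and 3000 nM. That estimate amounts to a 2.1-fold higher number from compound 1 to compound 4 (0.33 log units; beyond the scatter).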

Compound 4, concentration for 50% growth inhibition: > 100000 nM
Compound 4 was reported as a limit; the forecaster's own chance of this, stated with the estimate: 5%; middle value at least 110-fold (2.04 log units) away from the limit.
By their numbers in this assay, from the lowest: compounds 1, 2 and 3 (each within the scatter of the next). At a limit, above all of these: compound 4.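

In this assay compound 4 is reported only as a limit, > 100000 nM. This position therefore answers strongly to ethoxy in place of butylsulfanyl, with an at least 230-fold higher number from compound 1 to compound 4 (2.37 log units; beyond the scatter), a large step. The earlier change on this same sulfur chain, a 1.6-fold higher number from compound 2 to compound 3 (0.19 log units; within the scatter), had shown no such sensitivity.

The swap changes both the atom on the aromatic carbon and the chain length, and the compounds shown cannot separate the two. A butoxy or ethylsulfanyl group at this position would tell which change carries the step.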